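The source may report more compounds than this note shows. Statements on the series, on what has been measured and on what is new or still open speak of the compounds shown alone.

Measured in a functional assay on MCF7 cells (Homo sapiens) for antiproliferative activity, read by MTT assay, with a stated time of 24 h; a lower number here means a stronger inhibitor, a higher number a weaker inhibitor:
compound 1 `COc1nc(C)c(CCO)c(OC)n1`: > 100000 nM, a limit of the assay
compound 2 `COc1nc(C)c(CCF)c(OC)n1`: > 100000 nM, a limit of the assay
compound 3 `COc1nc(Cl)nc(C)c1CCF`: > 100000 nM, a limit of the assay

Compound 2 stands only at a limit in this assay, and the two further values in the series are limits as well, so compound 2 cannot be placed against its neighbours by the numbers shown. Compound 4 `COc1nc(C)c(CCOC(C)=O)c(OC)n1` differs from compound 2 by acetoxy in place of fluoro on a saturated chain carbon, two bonds along the chain from an aromatic carbon. Among the measured compounds shown here, no measured step touches an acetoxy group. The steps that are measured, a step that the two limits leave unreadable from compound 1 to compound 2 and a step that the two limits leave unreadable from compound 2 to compound 3, have no readable size, as every value sits at the limit of > 100000 nM in this assay, at which 3 of the 3 values shown sit. They give no direction for the change to compound 4, and nothing in the series shows a move into the measurable range of this assay. The step of a number no higher from compound 2 to compound 4 (the limit leaves the size open) is therefore estimated as no move beyond the scatter. Compound 4 is expected at 100000 nM, with a range from 30000 nM to 300000 nM, and most probably reported again as a limit rather than a number.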

Compound 4, half-maximal inhibitory concentration: 65000 nM
The estimate for compound 4 lay 1.5-fold (0.19 log units) above the measured number; the range from low to high includes it.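

In this assay, acetoxy in place of fluoro on a saturated chain carbon, two bonds along the chain from an aromatic carbon, gives an at least 1.5-fold lower number from compound 2 to compound 4 (0.18 log units; that floor lies within the scatter), and acetyl in place of hydrogen on the oxygen gives an at least 1.5-fold lower number from compound 1 to compound 4 (0.18 log units; that floor lies within the scatter). Among the compounds shown here, each of these is a floor, so the true size of both steps stays open, and the earlier steps cannot be read at all. This chain position is nonetheless the first place in the series where a change yields a number rather than a limit: the limit of > 100000 nM in this assay, at which 3 of the 4 values shown sit.

Still open, going by these compounds, is whether an amine, a carboxylic acid or a longer acyl chain at this position would move the number beyond the scatter. Also open, on these data alone, is how acetoxy behaves on the core of compound 3, which carries chloro in place of methoxy.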